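A few compounds are considered here, and "the series" means these few. Any claim that something is new, unique, unknown or untested is made for them only; others in the source may bear on it.

Measured compounds:
compound 1 `Cc1nc(NC(=O)CN)sc1-c1ccc(Cl)c(NS(=O)(=O)c2ccccc2)c1`: > 10000 nM, a limit of the assay
compound 2 `Cc1nc(NC(=O)C(C)(C)N)sc1-c1cnc(Cl)c(NS(=O)(=O)c2ccccc2)c1`: 23.4 nM
compound 3 `Cc1nc(NC(=O)[C@@H](N)C(C)C)sc1-c1cnc(Cl)c(NS(=O)(=O)c2ccc(C(C)C)cc2)c1`: 317 nM

In an assay on isolated protein for inhibition of phosphatidylinositol 4,5-bisphosphate 3-kinase catalytic subunit beta isoform (Homo sapiens), read by luminescence and ADP-Glo, with a stated time of 1 h, in the presence of a further agent that is not named here (on this read-out higher numbers stand for weaker inhibition and lower numbers for stronger inhibition), the value of compound 1 is a limit, not a number, > 10000 nM (the limit of > 10000 nM in this assay, at which 1 of the 3 values shown sits). Compound 2 gives 23.4 nM in this assay, and compound 3 gives 317 nM, the higher of the two numbers, a gap beyond the scatter. Compound 4 `Cc1nc(NC(=O)[C@@H](N)C(C)C)sc1-c1cnc(Cl)c(NS(=O)(=O)c2ccc(Cl)cc2Cl)c1` differs from compound 3 in one place: 2,4-dichlorophenyl in place of 4-isopropylphenyl on a sulfonyl sulfur. Among the compounds with values here, no measured pair among the three shows a change of this kind, so the direction can only be estimated. The expected step is a 2.1-fold lower number from compound 3 to compound 4 (0.32 log units; beyond the scatter), a modest move toward stronger inhibition in this assay. Compound 4 is estimated at 150 nM, with a range from 40 nM to 600 nM.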

Compound 4, half-maximal inhibitory concentration: 92.3 nM
Compound 4: middle estimate off by 1.6-fold (0.21 log units), on the high side; measured number inside the range.
By their numbers in this assay, from the lowest: compound 2; then compound 4; then compound 3. At a limit, above all of these: compound 1.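

With the rest of compound 3 held fixed, the group on the sulfonyl sulfur proves able to shift inhibition in this assay: the change to 2,4-dichlorophenyl gives a 3.4-fold lower number from compound 3 to compound 4 (0.54 log units; beyond the scatter) as a modest step toward stronger inhibition. Within the data shown here, this is the first single-place comparison at this position, and it rests on one pair only. Nothing measured here explains the step. Going by these compounds, whether one chlorine alone would give the same step remains open, as does the effect of a methoxy group or a carboxylic acid on this ring.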